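From Compound 3 to Compound 4: One Sulfonamide Exchanged

A few compounds are considered here, and "the series" means these few. Any claim that something is new, unique, unknown or untested is made for them only; others in the source may bear on it.

Measured compounds:
- compound 1, `CCN(CC)S(=O)(=O)c1ccc(S(=O)(=O)N2CCC[C@@H](C(=O)N[C@@H]3CCN(C(=O)OC(C)(C)C)C3)C2)cc1`: in a functional assay on MIA PaCa-2 cells (Homo sapiens) for inhibition, read by MTT assay, with a stated time of 3 days (a higher number here means a weaker inhibitor, a lower number a stronger inhibitor), compound 1 gives > 10000 nM, which is a limit of the assay rather than a number.
- compound 2, `CCOC(=O)[C@@H]1CCC[C@@H](S(=O)(=O)c2ccc(S(=O)(=O)N(CC)CC)cc2)C1`: in this assay compound 2 gives > 10000 nM, again only a limit.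
- compound 3, `CCCN(CCC)S(=O)(=O)c1ccc(S(=O)(=O)N2CCC[C@@H](C(=O)OCC)C2)cc1`: in this assay compound 3 gives > 10000 nM, once more a limit.

Compound 3 therefore stands at the limit, and it does not stand alone there: the limit of > 10000 nM in this assay, at which 3 of the 3 values shown sit. Nothing among these three compounds rises above the limit, so no measured step exists between any pair of them, and no ranking of compound 3 against compound 1 or compound 2 can be drawn.

Compound 4, `CCOC(=O)[C@@H]1CCCN(S(=O)(=O)c2ccc(S(=O)(=O)N3CCOCC3)cc2)C1`, is the next compound. It differs from compound 3 in one place: morpholin-4-yl in place of dipropylamino on a sulfonyl sulfur. The change is a morpholin-4-yl in place of dipropylamino on a sulfonyl sulfur whose other neighbour is an aromatic carbon. For the measured compounds named here, no measured step of any kind is available to say what such an exchange does in this assay.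

With every measured value sitting at the limit, the expectation for compound 4 is that it stays there as well, with no step beyond the usual scatter in either direction. The estimate for compound 4 is 15000 nM, expected to lie between 5000 nM and 50000 nM. This estimate implies a step that the limit leaves unreadable from compound 3 to compound 4, expected to be no real change.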

Compound 4, half-maximal inhibitory concentration: > 10000 nM
Compound 4: no number, only a limit; the forecaster's own chance of this, stated with the estimate: 85%; the middle value is on the limit's open side.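

Compound 4 joins compound 3 at the assay's limit, so no step can be read from compound 3 to compound 4, and the exchange of dipropylamino for morpholin-4-yl shows no size in this assay. All values shown remain limits: the limit of > 10000 nM in this assay, at which 4 of the 4 values shown sit.

The compounds shown leave open which structures, if any, would give a readable value in this assay.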